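Shortening the Side Group of Compound 1

A few compounds are considered here, and "the series" means these few. Any claim that something is new, unique, unknown or untested is made for them only; others in the source may bear on it.

Among the measured compounds shown here, in a functional assay on HCT-116 cells (Homo sapiens) for cytotoxicity, read by MTT assay, with a stated time of 72 h (on this read-out higher numbers stand for weaker inhibition and lower numbers for stronger inhibition), compound 1 `COc1ncc(-c2ccc3nc(NC(=O)NCC(=O)N4CCCCC4)nn3c2)cc1NS(=O)(=O)c1ccc(F)cc1` gives 130 nM, the lowest number of the three measured so far and so the strongest inhibition. Compound 2 `COc1ncc(-c2ccc3nc(NC(=O)N4CCCC4)nn3c2)cc1NS(=O)(=O)c1ccc(F)cc1` gives 1290 nM and compound 3 `COc1ncc(-c2ccc3nc(NC(=O)N(C)C)nn3c2)cc1NS(=O)(=O)c1ccc(F)cc1` gives 760 nM. These two lie within the scatter of each other (a 1.7-fold lower number from compound 2 to compound 3 (0.23 log units; within the scatter)). Compound 4 `COc1ncc(-c2ccc3nc(NC(=O)NC4CC4)nn3c2)cc1NS(=O)(=O)c1ccc(F)cc1` has not yet been measured. It differs from compound 1 in one place: cyclopropyl in place of ((piperidin-1-yl)carbonyl)methyl on an amide-type nitrogen.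

Two measured steps also take away the ((piperidin-1-yl)carbonyl)methyl group: a 9.9-fold higher number from compound 1 to compound 2 (1.00 log units; beyond the scatter) and a 5.8-fold higher number from compound 1 to compound 3 (0.77 log units; beyond the scatter). Both lead to weaker inhibition, and both lie beyond the scatter. Neither is the same change, however, since compound 4 keeps the amide hydrogen, which compounds 2 and 3 lack. For the measured compounds named here, a rise somewhat smaller than those two steps therefore seems likely, though only three compounds support this. In this assay the expected step is a 3.5-fold higher number from compound 1 to compound 4 (0.54 log units; beyond the scatter). For compound 4 the estimated value is 450 nM, with an expected range of 130 nM to 1400 nM.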

Compound 4, half-maximal inhibitory concentration: 90 nM
Estimate against measurement, compound 4: 5.0-fold (0.70 log units) above; measured number below the stated range.
By their numbers in this assay, from the lowest: compounds 4 and 1 (each within the scatter of the next); then compounds 3 and 2 (each within the scatter of the next).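

In this assay, compound 1 and compound 4 cannot be told apart (a 1.4-fold lower number from compound 1 to compound 4 (0.16 log units; within the scatter)), so at this amide-type nitrogen the whole ((piperidin-1-yl)carbonyl)methyl group, with its six-membered ring and carbonyl, can be replaced by the much smaller cyclopropyl without a measurable loss. The steps to compound 4 from the other two compounds are clear (an 8.4-fold lower number from compound 3 to compound 4 (0.93 log units; beyond the scatter) and a 14-fold lower number from compound 2 to compound 4 (1.16 log units; beyond the scatter)), and among these four compounds, the two that keep the amide hydrogen, compound 1 and compound 4, give the lower numbers. Nothing shown here gives a reason for this difference.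

Compounds 2 and 3 lose the amide hydrogen and also carry different groups, so the two changes cannot be separated. On these data alone, it remains open how a plain methyl, a cyclohexyl ring or a longer chain ending in an amine would fare on this nitrogen.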